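From fluoro to methyl on a compound at the assay limit

A few compounds are considered here, and "the series" means these few. Any claim that something is new, unique, unknown or untested is made for them only; others in the source may bear on it.

Compound 1 `N#Cc1ccc(NC(=O)c2ccc(C(F)(F)F)cc2O)cc1` gives 1440 nM
Compound 2 `O=C(Nc1ccc(C(F)(F)F)cc1)c1ccc(Cl)cc1O` gives 580 nM
Compound 3 `N#Cc1ccc(NC(=O)c2c(O)cccc2F)cc1` gives > 10000 nM

In a functional assay on KG-1 cells (Homo sapiens) for cytotoxicity, read by luminescence and CellTiter-Glo, with a stated time of 3 days (on this read-out higher numbers stand for weaker inhibition and lower numbers for stronger inhibition), compound 1 and compound 2 return numbers, while compound 3 does not. The reading for compound 3 is a limit and not a number (the limit of > 10000 nM in this assay, at which 1 of the 3 values shown sits).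

Compound 4 `Cc1cccc(O)c1C(=O)Nc1ccc(C#N)cc1` differs from compound 3 by methyl in place of fluoro on an aromatic carbon, ortho to a large group and meta to a hydroxy group (methyl in place of fluoro on an aromatic carbon). Among the compounds with values here, no pair of measured compounds shows this change on its own. Within the data shown here, the only guide is therefore the limit of compound 3 (> 10000 nM).

The step expected in this assay is small, with no direction beyond the scatter (a number no higher from compound 3 to compound 4 (the limit leaves the size open)). For compound 4 the estimate is 10000 nM within an expected range of 3000 nM to 30000 nM and the assay may well report only a limit once more.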

Compound 4, half-maximal inhibitory concentration: 7940 nM
Compound 4: middle estimate off by 1.3-fold (0.10 log units), on the high side, and the stated range covers the measured number.
By their numbers in this assay, from the lowest: compound 2; then compound 1; then compound 4. At a limit, above all of these: compound 3.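

In this assay methyl in place of fluoro on an aromatic carbon gives an at least 1.2-fold lower number from compound 3 to compound 4 (0.10 log units; that floor lies within the scatter). Compound 4 gives 7940 nM, so this position, ortho to a large group and meta to a hydroxy group, now carries a group with a measured number. The floor of the step does not show that methyl and fluoro differ here. The reading of compound 3 is a limit and not a number: the limit of > 10000 nM in this assay, at which 1 of the 4 values shown sits.

How far the true step runs cannot be read, and this single pair is all that speaks for the change. Going by these compounds, whether an amine, a carboxylic acid or a longer chain on this aromatic carbon would give a lower number than methyl stays open, as does whether the change would read the same on the core of compound 1 or compound 2.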